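The compounds below may be only part of what the source reports. "The series", "measured", "known", "first", "only" and "open" are said of these compounds alone.

Of the compounds shown here, two have so far been tested in an ADME assay on HEK293 cells (Homo sapiens) for cytotoxicity, read by CCK-8 assay and cell counting, with a stated time of 2 days; on this read-out lower numbers stand for stronger inhibition and higher numbers for weaker inhibition. Compound 1 `Oc1ccc(-c2cc(-c3ccc(Cl)cc3)nc(-c3ccsc3)c2)cc1` gives 4860 nM, while compound 2 `Oc1cccc(-c2cc(-c3ccc(Cl)cc3)nc(-c3ccccn3)c2)c1` gives 14000 nM, which puts compound 2 at the higher of the two numbers, a gap beyond the usual scatter. Compound 3 `Oc1ccc(-c2cc(-c3ccc(Cl)cc3)nc(-c3ccccn3)c2)cc1` differs from compound 2 in one place: 4-hydroxyphenyl in place of 3-hydroxyphenyl on an aromatic carbon. Among the compounds with values here, no measured pair shows this change on its own, so its effect in this assay remains open. The expected step of a 1.4-fold lower number from compound 2 to compound 3 (0.15 log units; within the scatter) is small, perhaps not beyond the scatter, in either direction. Compound 3 is therefore estimated to give about 10000 nM, within a range from 4000 nM to 25000 nM.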

Compound 3, half-maximal inhibitory concentration: 27200 nM
Compound 3: middle estimate off by 2.7-fold (0.43 log units), on the low side, and the stated range ends below it.
By their numbers in this assay, from the lowest: compound 1; then compounds 2 and 3 (each within the scatter of the next).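

In this assay the swap to 4-hydroxyphenyl in place of 3-hydroxyphenyl gives a 1.9-fold higher number from compound 2 to compound 3 (0.29 log units; within the scatter) and so cannot be told apart from repeat-measurement noise. Pyridin-2-yl in place of thiophen-3-yl, a change at a different place, gives a 5.6-fold higher number from compound 1 to compound 3 (0.75 log units; beyond the scatter) and is the first single-place change here to clear the scatter, so among these compounds only that exchange shows a real difference. As far as these compounds go, whether a methoxy group or an amine in place of the hydroxyl would shift the number stays open. Nothing available explains why the pyridin-2-yl compound reads higher.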